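The source may hold more compounds than are shown below. What is called first, only, known or untested is meant among the compounds shown, and "the series" means these compounds.

Measured compounds:
compound 1, `O=C(CN1CCC(c2cccc[n+]2[O-])CC1)Nc1cccc(F)c1`, 70%
compound 2, `O=C(CN1CCC(c2ccccn2)CC1)Nc1c(Cl)cc(Cl)cc1Cl`, 45%
compound 3, `O=C(CN1CCC(c2cccc[n+]2[O-])CC1)Nc1cccc(-c2ccccc2)c1`, 75%

In a functional assay on HEK293 cells for agonist activity at D(4) dopamine receptor (Homo sapiens), read by FLIPR (a lower number here means a smaller maximal response, a higher number a larger maximal response), compound 1 stands second highest of the three; compound 3 lies nearest, with a number 5 percentage points higher from compound 1 to compound 3 (within the scatter), and compound 2 lies furthest, its value beyond the scatter below that of compound 1. Compound 4, `O=C(CN1CCC(c2cccc[n+]2[O-])CC1)Nc1ccccc1F`, has not been measured in this assay. It differs from compound 1 by 2-fluorophenyl in place of 3-fluorophenyl on an amide-type nitrogen. Among the measured compounds shown here, no measured step moves a fluoro between ring positions; the only step on the amide-bound ring, from compound 1 to compound 3, replaces fluoro by phenyl and stays within the scatter. On that basis no step beyond the scatter is expected for compound 4 in this assay, and the expected step is a number 4 percentage points lower from compound 1 to compound 4 (within the scatter). Compound 4 is estimated at 66%, between 50% and 82%.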

Compound 4, largest response reached (reported as efficacy), in percent of the reference or control that the assay uses: 63%
Beside the measured number, compound 4's estimate is 3 percentage points above it; the range from low to high includes it.
By their numbers in this assay, from the lowest: compound 2; then compounds 4, 1 and 3 (each within the scatter of the next, the first and the last beyond it).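

In this assay, 2-fluorophenyl in place of 3-fluorophenyl on an amide-type nitrogen gives a number 7 percentage points lower from compound 1 to compound 4 (within the scatter). The earlier compounds shown here showed only fluoro replaced by phenyl on this ring, whereas this step shows that moving the fluoro, with the atoms of the group unchanged, also leaves the maximal response within the scatter. Nothing at hand explains this result.

The compounds shown leave open whether a methoxy group or an amine in place of the fluoro would also stay within the scatter. They also leave open whether moving the fluoro gives a similar step in any other assay.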